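Swapping the branched side chain on a fused core

A few compounds are considered here, and "the series" means these few. Any claim that something is new, unique, unknown or untested is made for them only; others in the source may bear on it.

Compound 2 `CCCC(C)n1c(=O)c(C)nc2c(-c3ccc(Cl)cc3Cl)ccnc21` gives 62 nM in a functional assay for antagonist activity at corticotropin-releasing factor receptor 1 (Rattus norvegicus); on this read-out higher numbers stand for weaker inhibition and lower numbers for stronger inhibition.
Compound 1 `CC[C@H](COC)n1c(=O)c(C)nc2c(-c3ccc(Cl)cc3Cl)nccc21` gives 150 nM in this assay.
Compound 3 `CC[C@H](C1CC1)n1c(=O)c(C)nc2c(-c3cc(C)c(OC)nc3C)ccnc21` gives 15 nM in this assay.

Compound 2 stands between the others: its number is beyond the scatter below that of compound 1 and beyond the scatter above that of compound 3. Compound 4 `CC[C@@H](C1CC1)n1c(=O)c(C)nc2c(-c3ccc(Cl)cc3Cl)ccnc21` has not been measured. It differs from compound 2 in one place: 1-cyclopropylpropyl in place of 1-methylbutyl on an aromatic nitrogen. Compound 3 carries the same 1-cyclopropylpropyl group, though on a different core, and its value of 15 nM is the lowest shown. A modest move toward stronger inhibition is therefore expected, a 2.1-fold lower number from compound 2 to compound 4 (0.32 log units; beyond the scatter), about the scatter or a little beyond. Compound 4 is estimated at 30 nM, in the range 10 nM to 100 nM.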

Compound 4, half-maximal inhibitory concentration: 7.4 nM
Compound 4: middle estimate off by 4.1-fold (0.61 log units), on the high side; the measured number lies below the stated range.
By their numbers in this assay, from the lowest: compound 4; then compound 3; then compound 2; then compound 1.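

Among these compounds, on the shared core, the group on this aromatic nitrogen strongly affects the result: in this assay, 1-cyclopropylpropyl in place of 1-methylbutyl gives an 8.4-fold lower number from compound 2 to compound 4 (0.92 log units; beyond the scatter) and provides the first direct reading of a change at this position. The earlier compounds shown here could not show this, as no two of them differ in only one place. Nothing shown explains the size of this step.

Still open, on these data alone, is whether a larger ring, such as a cyclobutyl or cyclopentyl group, would serve as well here. It is also unknown whether the mirror-image form of 1-cyclopropylpropyl would give a similar number.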